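This account rests on a few compounds, and the source may have more. Where it says the series, first, only, none or still open, it means among the compounds named here.

Measured so far in an ADME assay on Caco-2 cells (Homo sapiens) for permeability, in the apical to basolateral direction; a higher number here means that the compound crosses the layer faster, a lower number that the compound crosses the layer more slowly:
compound 1, `CCCS(=O)(=O)Nc1ccc(F)c(C(=O)Nc2cnc3[nH]ncc3c2)c1F`, gives 1.3 10^-6 cm/s
compound 2, `CCCS(=O)(=O)Nc1ccc(F)c(C(=O)Nc2cnc3ccnn3c2)c1F`, gives 11.4 10^-6 cm/s
compound 3, `CCCS(=O)(=O)Nc1ccc(F)c(C(=O)Nc2cnc3[nH]cnc3c2)c1F`, gives 0.6 10^-6 cm/s

Compound 3 stands lowest of the three. Compound 1 is the nearest to it, a 2.2-fold lower number from compound 1 to compound 3 (0.34 log units; beyond the scatter); compound 2 is the furthest, a 19-fold lower number from compound 2 to compound 3 (1.28 log units; beyond the scatter). Within the three, only the bicyclic group on the amide nitrogen changes, and that exchange alone spans the whole spread: an 8.8-fold higher number from compound 1 to compound 2 (0.94 log units; beyond the scatter).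

Compound 4, `CCCS(=O)(=O)Nc1ccc(F)c(C(=O)Nc2cnc3[nH]c(-c4ccc(Cl)c(Cl)c4)nc3c2)c1F`, differs from compound 3 by 3,4-dichlorophenyl in place of hydrogen on an aromatic carbon. For the measured compounds named here, none of the measured steps bears on this change directly. Going by the values given here, each of them replaces one bicyclic group by another of the same size; no measured pair differs by a group added onto a carbon of the five-membered ring while the rest of the molecule stays the same. Among the compounds with values here, no direction for this step can therefore be read from the series, and the estimate for compound 4 in this assay has to carry a wide range. Compound 4 is expected to give about 1.2 10^-6 cm/s in this assay, with a range from 0.3 10^-6 cm/s to 5 10^-6 cm/s. The step thus expected is a 2.0-fold higher number from compound 3 to compound 4 (0.30 log units; within the scatter), which may or may not end up beyond the scatter.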

Compound 4, apparent permeability: 2 10^-6 cm/s
Compound 4: middle estimate off by 1.7-fold (0.22 log units), on the low side; the range from low to high includes it.
By their numbers in this assay, from the lowest: compound 3; then compounds 1 and 4 (each within the scatter of the next); then compound 2.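

In this assay, the aromatic carbon between two ring nitrogen atoms carries 3,4-dichlorophenyl in place of hydrogen with a rise in the number (a 3.3-fold higher number from compound 3 to compound 4 (0.52 log units; beyond the scatter)), so this added group of carbon and chlorine atoms brings no loss at this position. For the compounds shown here, all earlier steps exchanged one bicyclic group for another of the same size, whereas this is the first measured addition onto a carbon of the five-membered ring, and it shows that the number can respond to a change at this position as well as to the make-up of the bicyclic group. No measurement at hand accounts for the rise.

As far as these compounds go, whether the rise belongs to the phenyl ring, to its two chlorine atoms or to any group at this carbon stays open; an unsubstituted phenyl, a methyl, or a phenyl bearing an amine or a carboxylic acid would separate these cases. Also open, from the compounds shown here alone, is whether 3,4-dichlorophenyl added to the bicyclic groups of compound 1 or compound 2 would move the number in the same direction.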